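Chloro to hydrogen on an aromatic carbon across two cores

The source may report more compounds than this note shows. Statements on the series, on what has been measured and on what is new or still open speak of the compounds shown alone.

Compound 1 `O=c1c(C(=S)Nc2ccccc2)coc2cc(Cl)ccc12` is a thioanilide on one core; compound 2 `O=c1c(C2N=C(c3ccccc3)SS2)coc2cc(Cl)ccc12` and compound 3 `O=c1c(C2N=C(c3ccccc3)SS2)coc2ccccc12` carry a different core, and the difference between the two cores is not broken down here. In a functional assay on HEp-2 cells (Homo sapiens) for inhibition, read by sulforhodamine B assay, with a stated time of 48 h (a higher number here means a weaker inhibitor, a lower number a stronger inhibitor), compound 1 gives only a limit, > 100000 nM. In this assay compound 2 likewise gives only a limit, > 100000 nM. In this assay compound 3 also gives only a limit, > 100000 nM. The change hydrogen in place of chloro on an aromatic carbon therefore yields a step that the two limits leave unreadable from compound 2 to compound 3, because of the limit of > 100000 nM in this assay, at which 3 of the 3 values shown sit.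

Compound 4 `O=c1c(C(=S)Nc2ccccc2)coc2ccccc12` is not yet measured. It stands to compound 1 as compound 3 stands to compound 2: hydrogen in place of chloro on an aromatic carbon, the same change on the same kind of aromatic carbon. Set beside the earlier step, a step that the two limits leave unreadable from compound 2 to compound 3, the step from compound 1 to compound 4 is expected to be a step that the limit leaves unreadable from compound 1 to compound 4, since compound 1 itself sits at the limit, (the limit of > 100000 nM in this assay, at which 3 of the 3 values shown sit). In this assay compound 4 is therefore estimated at 200000 nM, with a range from 50000 nM to 1000000 nM.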

Compound 4, half-maximal inhibitory concentration: > 100000 nM
Compound 4 ended at the assay's limit (the forecaster's own chance of this, stated with the estimate: 85%); the middle value does not contradict the limit.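

No step can be read from compound 1 to compound 4, and the result adds no other readable comparison, because all the compounds share one limit: the limit of > 100000 nM in this assay, at which 4 of the 4 values shown sit.

The compounds shown leave open whether hydrogen in place of chloro on this aromatic carbon changes inhibition on either core in this assay, as none gives a value beyond a limit.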